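The compounds below may be only part of what the source reports. "The series", "measured", "known", "first", "only" and "open" are said of these compounds alone.

Measured compounds:
Compound 1, `CC1C(=O)N(CCCCCOc2ccc(Cl)cc2)/C(=N\C#N)N1c1ccncc1`: 1780 nM
Compound 2, `CC1C(=O)N(CCCCCCOc2ccc(Cl)cc2)/C(=N\C#N)N1c1ccncc1`: 214 nM
Compound 3, `N#C/N=C1\N(CCCCCCOc2ccc(Cl)cc2)C(=O)CCN1c1ccncc1`: 288 nM

Of the compounds shown here, three have been tested in a functional assay on NUGC cells (stomach, Homo sapiens) for cytotoxicity; on this read-out lower numbers stand for stronger inhibition and higher numbers for weaker inhibition. Compound 1 has the shortest chain of the three and, in this assay, gives 1780 nM. Among the compounds with values here, compound 2 carries one more chain carbon, and the step of an 8.3-fold lower number from compound 1 to compound 2 (0.92 log units; beyond the scatter) is the only single-point comparison among the measured compounds; the change is (4-chlorophenoxy)methyl in place of 4-chlorophenoxy on a saturated chain carbon, five bonds along the chain from an amide-type nitrogen in a ring.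

Compound 3 sits on a different core, and the difference between the core of compound 3 and the core of compound 1 is not broken down here. In this assay compound 3 gives 288 nM, and compared with compound 2 this is within the scatter, so nothing can be said of any order between these two.

Compound 4, `N#C/N=C1\N(CCCCCCCOc2ccc(Cl)cc2)C(=O)CCN1c1ccncc1`, has not yet been measured. It differs from compound 3 by (4-chlorophenoxy)methyl in place of 4-chlorophenoxy on a saturated chain carbon, six bonds along the chain from an amide-type nitrogen in a ring. This is the same kind of change as that from compound 1 to compound 2, but the place is not the same: there it was five bonds along the chain from the amide-type nitrogen in the ring, here it is six. The expectation for compound 4 rests on the step of an 8.3-fold lower number from compound 1 to compound 2 (0.92 log units; beyond the scatter) seen in the other core, tempered by the fact that compound 3 already carries the longer chain. The step from compound 3 to compound 4 is expected to be a 2.2-fold lower number from compound 3 to compound 4 (0.35 log units; beyond the scatter), smaller than the earlier one. Compound 4 is therefore estimated at 130 nM, with a range from 40 nM to 450 nM.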

Compound 4, half-maximal inhibitory concentration: 1100 nM
The estimate for compound 4 lay 8.5-fold (0.93 log units) below the measured number, and the stated range ends below it.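

In this assay the same one-carbon lengthening of the chain that gave an 8.3-fold lower number from compound 1 to compound 2 (0.92 log units; beyond the scatter) on the core of compound 1 gives a 3.8-fold higher number from compound 3 to compound 4 (0.58 log units; beyond the scatter) on the core of compound 3, so the change runs in the opposite direction. Set side by side, the two steps show that the gain seen on one core did not carry over to the other: the same change on two cores in this assay, an 8.3-fold lower number (0.92 log units; beyond the scatter) from compound 1 to compound 2 and a 3.8-fold higher number (0.58 log units; beyond the scatter) from compound 3 to compound 4, 32-fold (1.50 log units) apart, beyond the scatter of two such steps. Within the data shown here, this does not show whether the reversal belongs to the core or to the place of the change, which lies five bonds along the chain from the amide-type nitrogen in one pair and six in the other, and the two pairs differ in both, with only one pair on each core.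

The compounds shown leave open whether the core of compound 1 would respond in the same way when given the chain of compound 4, and how the core of compound 3 would behave with the shorter chain of compound 1. They also leave open what a still longer chain would do on either core, or whether bromine in place of the chlorine on the phenoxy group would alter these steps.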